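A few compounds are considered here, and "the series" means these few. Any claim that something is new, unique, unknown or untested is made for them only; others in the source may bear on it.

Measured so far in a toxicity assay on A549 cells (Homo sapiens) for cytotoxicity, read by luminescence and CellTiter-Glo, with a stated time of 48 h; on this read-out higher numbers stand for lower toxicity in this test and lower numbers for higher toxicity in this test:
Compound 1 `CCCCOc1ccc(-c2nc3ncccn3c2NCc2nc[nH]c2C)cc1` gives 100000 nM.
Compound 2 `O=C(O)CCCOc1ccc(-c2nc3ncccn3c2NC2CCCCC2)cc1` gives only a limit, > 100000 nM.

Compound 2 thus stands at the edge of what this test can report: the limit of > 100000 nM in this assay, at which 1 of the 2 values shown sits. Among the compounds with values here, because compound 1 has a number and compound 2 only a limit, no measured step between the two can be read, and the pair shows only that both sit at the low-toxicity end of this assay.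

Compound 3 `Oc1ccc(-c2nc3ncccn3c2NC2CCCCC2)cc1` differs from compound 2 in one place: hydrogen in place of 3-carboxypropyl on an oxygen on an aromatic ring. Within the data shown here, with no measured step to lean on, the expected change in this assay is small and without a clear direction, likely within the usual scatter, while the chance that this assay again reports only a limit stays considerable.

Compound 3 is therefore expected to give about 80000 nM, in a range from 20000 nM to 200000 nM. This estimate means an expected step of an at least 1.2-fold lower number from compound 2 to compound 3 (0.09 log units; that floor lies within the scatter).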

Compound 3, half-maximal cytotoxic concentration: > 100000 nM
Compound 3: a limit, no number (the forecaster's own chance of this, stated with the estimate: 45%); middle value at least 1.2-fold (0.09 log units) from the limit.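

In this assay, compound 2 and compound 3 both give only a limit, not a number, so no step can be read between them: the limit of > 100000 nM in this assay, at which 2 of the 3 values shown sit.

As far as these compounds go, whether hydrogen in place of 3-carboxypropyl on the oxygen changes the result in this assay at all stays open.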